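Swapping iodine for chlorine on the benzimidazole-type core

The source may report more compounds than this note shows. Statements on the series, on what has been measured and on what is new or still open speak of the compounds shown alone.

Measured so far:
- compound 1, `CCc1ccc2[nH]c(CC(CC(=O)O)c3ccc(Cl)cc3)nc2c1`: 0%
- compound 2, `N#Cc1ccc2[nH]c(CC(CC(=O)O)c3ccc(Cl)cc3)nc2c1`: 0%
- compound 3, `O=C(O)CC(Cc1nc2cc(I)ccc2[nH]1)c1cccc(Cl)c1`: 70%

All three were tested in an assay on isolated protein for inhibition of protein kinase C zeta type (Homo sapiens), read by 33P incorporation, tested at 200 uM; a lower number here means a weaker effect, a higher number a stronger effect of the compound at the concentration tested. Compound 3 stands highest of the three numbers, and its gap to compound 1 and to compound 2 lies beyond the scatter, so it is the strongest of the measured set. Within the data shown here, the one step measured between two compounds that differ in a single place is no change at the digits printed from compound 1 to compound 2 (within the scatter); it concerns a different change, and both of those compounds sit at the bottom of the read-out, so it says little about what a change on compound 3 will do.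

Compound 4, `O=C(O)CC(Cc1nc2cc(Cl)ccc2[nH]1)c1cccc(Cl)c1`, differs from compound 3 by chloro in place of iodo on an aromatic carbon. Among the measured compounds shown here, no measured step covers a change of this kind here, so the expectation rests on compound 3 alone. Because compound 3 gives 70%, compound 4 is expected to remain clearly active, with an estimated step of a number 20 percentage points lower from compound 3 to compound 4 (beyond the scatter). The estimate for compound 4 is 50%, expected to fall between 20% and 80%.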

Compound 4, a percentage reported as inhibition, at one concentration (the size of the read-out at that concentration, not a potency): 0%
The estimate for compound 4 lay 50 percentage points above the measured number; the measured number lies below the stated range.
By their numbers in this assay, from the lowest: compounds 1, 2 and 4 (each within the scatter of the next); then compound 3.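

In this assay, the step of a number 70 percentage points lower from compound 3 to compound 4 (beyond the scatter) shows that the effect of compound 3 depends strongly on the group at this aromatic carbon of the shared core. The earlier step, between two compounds at the bottom of the read-out, could not reveal a loss of this kind, whereas this one does, even though iodo and chloro match in the counts of heavy atoms, hydrogen-bond donors and acceptors, and net charge. No evidence at hand explains why the effect disappears with this exchange.

The compounds shown leave open whether bromo, the halogen not among them, would keep any of the effect at this carbon. They also leave open how an amine or a methoxy group would behave there, and whether iodo would give a similar read-out with the chlorine on the other ring moved to the position it holds in compound 1.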